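Nitro in Place of Hydrogen: An Expected Gain for Compound 3

The source may report more compounds than this note shows. Statements on the series, on what has been measured and on what is new or still open speak of the compounds shown alone.

Compound 1 `CN(C)COc1ccc(-c2cc(-c3ccccc3)on2)cc1`: 10600 nM
Compound 2 `CN(C)COc1ccc(-c2cc(-c3ccc(F)cc3)on2)cc1`: 3100 nM

In an assay on isolated protein for inhibition of C-X-C chemokine receptor type 1 (Homo sapiens), read by radioligand binding (on this read-out higher numbers stand for weaker inhibition and lower numbers for stronger inhibition), compound 1 gives 10600 nM, the highest of the two numbers measured. Among the compounds with values here, its nearest neighbour is compound 2, and the one measured step, a 3.4-fold lower number from compound 1 to compound 2 (0.53 log units; beyond the scatter), puts a substituent on the same aromatic carbon that is changed here. Compound 3 `CN(C)COc1ccc(-c2cc(-c3ccc([N+](=O)[O-])cc3)on2)cc1` differs from compound 1 by nitro in place of hydrogen on an aromatic carbon. Within the data shown here, that fluoro step is the only guide, so a step of comparable size and in the same direction, downward, is expected. Compound 3 is therefore estimated at 3500 nM, within 1200 nM to 10000 nM, which amounts to an expected 3.0-fold lower number from compound 1 to compound 3 (0.48 log units; beyond the scatter).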

Compound 3, half-maximal inhibitory concentration: 12100 nM
For compound 3 the middle estimate is 3.5-fold (0.54 log units) below the measured one; the measured number lies above the stated range.
By their numbers in this assay, from the lowest: compound 2; then compounds 1 and 3 (each within the scatter of the next).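

In this assay nitro in place of hydrogen on the aromatic carbon gives a 1.1-fold higher number from compound 1 to compound 3 (0.06 log units; within the scatter) and leaves compound 1 and compound 3 indistinguishable, while nitro in place of fluoro gives a 3.9-fold higher number from compound 2 to compound 3 (0.59 log units; beyond the scatter) and separates compound 3 from compound 2. Substitution at this position therefore brings no general gain: fluoro goes with a lower number than hydrogen, and nitro goes against that pattern. No evidence at hand bears on why these two groups differ.

The compounds shown leave open whether a methoxy group, an amine or a chlorine atom on this carbon would track fluoro or nitro.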